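The source may report more compounds than this note shows. Statements on the series, on what has been measured and on what is new or still open speak of the compounds shown alone.

The measured compounds:

Compound 1, `Cc1cccc(S(=O)(=O)Nc2ccc(-c3nc4ccccc4o3)cc2)c1`, gives > 100000 nM in an ADME assay on HEK293 cells (Homo sapiens) for cytotoxicity, read by resazurin assay, with a stated time of 48 h (a higher number here means that more compound is tolerated, a lower number that less compound is tolerated), which is a limit of the assay and not a number.

Compound 2, `O=S(=O)(Nc1ccc(-c2nc3ccccc3o2)cc1)c1cccc(C(F)(F)F)c1`, gives > 100000 nM in this assay, again a limit rather than a number.

Compound 2 therefore stands at the upper boundary of what was measured: the limit of > 100000 nM in this assay, at which 2 of the 2 values shown sit. The step that the two limits leave unreadable from compound 1 to compound 2 has no readable size, since both of its ends sit at that limit.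

The next compound, compound 3, `O=S(=O)(Nc1ccc(-c2nc3ccccc3o2)cc1)c1cccc(O)c1`, differs from compound 2 by hydroxy in place of trifluoromethyl on an aromatic carbon. For the measured compounds named here, the only measured step that bears on it is a step that the two limits leave unreadable from compound 1 to compound 2, a change at the same aromatic carbon, and it is unreadable. Going by the values given here, no measured step therefore shows any movement in this assay, and a step of no size beyond the scatter is expected, most likely ending in a further limit.

Compound 3 is thus expected to give 100000 nM in this assay, with a range from 40000 nM to 300000 nM. The expected step of a number no higher from compound 2 to compound 3 (the limit leaves the size open) is accordingly estimated to be flat.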

Compound 3, half-maximal cytotoxic concentration: > 100000 nM
Compound 3: only a limit was reported; the forecaster's own chance of this, stated with the estimate: 80%; the middle value lies on the limit itself.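

Compound 3 gives > 100000 nM in this assay, which is a limit of the assay and not a number. For the compounds shown here, no step among compound 1, compound 2 and compound 3 can be read, and all three stand at one boundary: the limit of > 100000 nM in this assay, at which 3 of the 3 values shown sit. The compounds shown leave open what half-maximal cytotoxic concentration any of the three has, and whether methyl, trifluoromethyl and hydroxy on this aromatic carbon differ in this assay.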